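From a Benzyl Arm to a 3-Methoxyphenyl Arm

The compounds below may be only part of what the source reports. "The series", "measured", "known", "first", "only" and "open" are said of these compounds alone.

Measured compounds:
compound 1, `CCN1CCN(c2ccc(Nc3ncc(Cl)c(Nc4ccccc4C)n3)cc2)CC1`, 3160 nM
compound 2, `CN1CCN(c2ccc(Nc3ncc(Cl)c(NCc4ccccc4)n3)nc2)CC1`, 17300 nM

Of the compounds shown here, two have been measured in a functional assay on MCF7 cells (Homo sapiens) for inhibition, read by CCK-8 assay, with a stated time of 48 h; a lower number here means a stronger inhibitor of growth, a higher number a weaker inhibitor of growth. Compound 1 gives 3160 nM, while compound 2 gives 17300 nM. Compound 2 stands at the highest of the two numbers, so it is the weaker inhibitor of growth, and its gap to compound 1 lies beyond the usual scatter. The two differ in several places at once, so their values can only be compared as a whole and no single change can be read from them.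

Compound 3, `COc1cccc(Nc2nc(Nc3ccc(N4CCN(C)CC4)cn3)ncc2Cl)c1`, has not yet been measured. It differs from compound 2 in one place:

3-methoxyphenyl in place of benzyl on a nitrogen on an aromatic ring

Among the compounds with values here, no measured pair mirrors this change, so the expectation rests on little. A moderate step downward, towards a stronger inhibitor of growth, is expected: a 3.8-fold lower number from compound 2 to compound 3 (0.58 log units; beyond the scatter). Compound 3 is therefore estimated to give 4500 nM, within a range from 1500 nM to 14000 nM.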

Compound 3, concentration for 50% growth inhibition: 7540 nM
Compound 3: the middle estimate sits 1.7-fold (0.22 log units) below what was measured; measured number inside the range.
By their numbers in this assay, from the lowest: compound 1; then compound 3; then compound 2.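

Within the data shown here, putting 3-methoxyphenyl in place of benzyl gives a 2.3-fold lower number from compound 2 to compound 3 (0.36 log units; beyond the scatter) in this assay and so offers the first comparison here in which only one place differs. It shows that the group on this nitrogen affects growth inhibition, and that this change moves the number modestly towards a stronger inhibitor. The change alters more than one feature, as benzylamino becomes (3-methoxyphenyl)amino and a methoxy oxygen enters, and nothing available here explains the shift.

From the compounds shown here alone, what remains open is whether the step comes from replacing benzyl with an aryl group or from the methoxy group itself, which a plain phenyl on this nitrogen could help separate. It is also unknown how a hydroxy group or an amine would compare with the methoxy group on this ring.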